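Swapping the aryl group: compound 3 to compound 4

The compounds below may be only part of what the source reports. "The series", "measured", "known", "first", "only" and "open" are said of these compounds alone.

In a functional assay on A549 cells (Homo sapiens) for antiproliferative activity, read by MTT assay, with a stated time of 72 h (on this read-out lower numbers stand for stronger inhibition and higher numbers for weaker inhibition), compound 1 (`COc1cc(-n2cnc3ccc(-c4ccccc4Cl)cc32)cc(OC)c1OC`) reports > 10000 nM as a limit only. Compound 2 (`COc1cc(-n2cnc3ccc(-c4ccc(C)cc4F)cc32)cc(OC)c1OC`) reports > 10000 nM as a limit too. Within the data shown here, compound 3 (`COc1cc(-n2cnc3ccc(-c4ccc([N+](=O)[O-])cc4)cc32)cc(OC)c1OC`) gives 8940 nM as the only true number in the set. The rest of the picture is the limit of > 10000 nM in this assay, at which 2 of the 3 values shown sit, and nothing firmer.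

Compound 4 (`COc1cc(-n2cnc3ccc(-c4cccc(F)c4)cc32)cc(OC)c1OC`) is still unread. The change leading to it is 3-fluorophenyl in place of 4-nitrophenyl on an aromatic carbon.

Two measured steps end on the 4-nitrophenyl group of compound 3. One is an at least 1.1-fold lower number from compound 1 to compound 3 (0.04 log units; that floor lies within the scatter) and the other is an at least 1.1-fold lower number from compound 2 to compound 3 (0.04 log units; that floor lies within the scatter) in the same read-out. Both are floors only, and the third step (a step that the two limits leave unreadable from compound 1 to compound 2) gives no size.

Compound 2 carries a fluorine-bearing phenyl group and stands at the limit > 10000 nM in this series, so compound 4 is expected to sit close to that limit. In this assay the expectation is no step beyond the scatter (a 1.1-fold higher number from compound 3 to compound 4 (0.05 log units; within the scatter)) with any drift towards the higher number. The estimate for compound 4 is 10000 nM with an expected range from 4000 nM to 25000 nM on this read-out, and a result reported only as a limit is quite possible.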

Compound 4, half-maximal inhibitory concentration: 5270 nM
Compound 4: the middle estimate sits 1.9-fold (0.28 log units) above what was measured; the range from low to high includes it.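

In this assay, among these compounds, the step of a 1.7-fold lower number from compound 3 to compound 4 (0.23 log units; within the scatter) is the first at this position with a true number at both ends, and it lies within the scatter, so 3-fluorophenyl and 4-nitrophenyl are not told apart here, although the two hydrogen-bond acceptors of 4-nitrophenyl are absent from 3-fluorophenyl. The steps of an at least 1.8-fold lower number from compound 2 to compound 4 (0.27 log units; that floor lies within the scatter) and an at least 1.8-fold lower number from compound 1 to compound 4 (0.27 log units; that floor lies within the scatter) are floors that lie within the scatter, so 3-fluorophenyl is not yet separated from 2-fluoro-4-methylphenyl or from 2-chlorophenyl. A fluorine on the phenyl group does not by itself place a compound at the limit, as compound 4 gives a true number and compound 2 does not, but the series remains only partly resolved: the limit of > 10000 nM in this assay, at which 2 of the 4 values shown sit.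

Among the compounds shown here, it remains open whether any group at this position gives a step beyond the scatter, and whether moving one substituent around the phenyl ring matters, as no pair here keeps the substituent fixed and changes only its place. An amine or a carboxylic acid on the phenyl ring, or a longer chain in place of that ring, would test how far this position tolerates change.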